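This account rests on a few compounds, and the source may have more. Where it says the series, first, only, none or still open, it means among the compounds named here.

Series so far:
- compound 1 `O=C(Nc1ccc(F)c(F)c1F)NC1CCCCC1`: 15.9 ug/mL
- compound 2 `CCCCCCCNC(=O)Nc1cccc(C(F)(F)F)c1F`: "not determined" (no result reported)
- compound 3 `O=C(NCc1cccc(Cl)c1)Nc1cccc(C(F)(F)F)c1F`: not yet measured

Among the compounds with values here, in an ADME assay on Vero cells (Chlorocebus sabaeus) for cytotoxicity, read by MTT assay, with a stated time of 72 h (a higher number here means a weaker inhibitor, a lower number a stronger inhibitor), compound 1 gives 15.9 ug/mL, the only number. Compound 2 has no number to place it: its entry reads "not determined" (no result reported). Within the data shown here, it therefore cannot serve as a starting point, and no measured step is available to size the coming change.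

The change is 3-chlorophenyl in place of hexyl on a saturated chain carbon bound to an amide-type nitrogen. In words, 3-chlorophenyl stands in place of hexyl on a saturated chain carbon bound to an amide-type nitrogen.

Among the measured compounds shown here, with no measured step in this assay, no direction can be argued for this change. The working expectation is a result no further from compound 1 at 15.9 ug/mL than the usual scatter, held loosely since that single value is the only anchor. The range is kept wide for the same reason.

In this assay the expected value for compound 3 is 15 ug/mL, with an estimated range from 5 ug/mL to 50 ug/mL.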

Compound 3, half-maximal inhibitory concentration: 193 ug/mL
Beside the measured number, compound 3's estimate is 13-fold (1.11 log units) below it, outside the stated range (above it).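

In this assay no new step can be read: compound 2 has no number, so compound 3 at 193 ug/mL has no measured partner that differs in one place. Nothing available bears on the reason for this value. The compounds shown leave open how 3-chlorophenyl compares with hexyl on the saturated chain carbon bound to an amide-type nitrogen.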